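Swapping the aryl group on the sulfonamide nitrogen

The compounds below may be only part of what the source reports. "The series", "measured", "known", "first", "only" and "open" are said of these compounds alone.

Measured so far in a functional assay on RAW264.7 cells (Mus musculus) for inhibition; on this read-out higher numbers stand for weaker inhibition and lower numbers for stronger inhibition:
- compound 1 `CCOC(=O)C1=CCCCC1S(=O)(=O)Nc1ccccc1F` gives 75 nM
- compound 2 `CCOC(=O)C1=CCCCC1S(=O)(=O)Nc1ccccc1Cl` gives 12 nM
- compound 3 `CCOC(=O)C1=CCCCC1S(=O)(=O)Nc1ccc(C#N)cc1Cl` gives 1600 nM

Compound 2 has the lowest number of the three, and its steps to both others lie beyond the scatter. Next is compound 4 `CCOC(=O)C1=CCCCC1S(=O)(=O)Nc1nccs1`, with 1,3-thiazol-2-yl in place of 2-chlorophenyl on a sulfonamide nitrogen. Among the measured compounds shown here, no measured step exchanges the whole group. The closest evidence is a 6.3-fold lower number from compound 1 to compound 2 (0.80 log units; beyond the scatter) and a 130-fold higher number from compound 2 to compound 3 (2.12 log units; beyond the scatter), both changes on the aromatic carbons of this group. Given a 130-fold higher number from compound 2 to compound 3 (2.12 log units; beyond the scatter), a large step to a higher number is expected in this assay. The expected step is a 67-fold higher number from compound 2 to compound 4 (1.82 log units; beyond the scatter). Compound 4 is estimated at 800 nM, with an expected range of 100 nM to 6000 nM.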

Compound 4, half-maximal inhibitory concentration: > 10000 nM
Compound 4 ended at the assay's limit (the forecaster's own chance of this, stated with the estimate: 15%); at least 12-fold (1.09 log units) between middle value and limit.
By their numbers in this assay, from the lowest: compound 2; then compound 1; then compound 3. At a limit, above all of these: compound 4.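

In this assay compound 4 gives > 10000 nM, a limit of the assay and not a number: the limit of > 10000 nM in this assay, at which 1 of the 4 values shown sits.

Exchanging the whole aryl group on the sulfonamide nitrogen for 1,3-thiazol-2-yl gives an at least 830-fold higher number from compound 2 to compound 4 (2.92 log units; beyond the scatter) and an at least 130-fold higher number from compound 1 to compound 4 (2.12 log units; beyond the scatter), so the steps from both halogenated phenyl compounds end at this limit. Activity at this position thus depends on more than the substituents on the phenyl ring, which were the only changes seen earlier.

The 1,3-thiazol-2-yl group changes ring size and hetero atoms together, and the compounds shown do not separate the two. From the compounds shown here alone, whether a six-membered ring with nitrogen, such as pyridin-2-yl, keeps the activity stays open.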